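Repeating a Methoxy Addition on a Second Core

The source may hold more compounds than are shown below. What is called first, only, known or untested is meant among the compounds shown, and "the series" means these compounds.

Three compounds were tested in a functional assay on MDA-MB-468 cells (Homo sapiens) for cytotoxicity, read by sulforhodamine B assay, with a stated time of 48 h, tested at 100 uM; on this read-out higher numbers stand for a weaker effect at the one concentration tested and lower numbers for a stronger effect. Compound 1 `COc1ccc(-c2cc(/C=C/C(=O)c3ccc(N)cc3)[nH]n2)cc1` gives -51%. Compound 3 `COc1ccc(-c2cc(/C=C/C(=O)c3ccc(N)cc3)[nH]n2)cc1OC` carries methoxy in place of hydrogen on an aromatic carbon and gives -73%, so that the step of a number 22 percentage points lower from compound 1 to compound 3 (beyond the scatter). Compound 2 `COc1ccc(C(=O)/C=C/c2cc(-c3cc(OC)c(OC)c(OC)c3)n[nH]2)cc1OC` rests on a different core, and the difference between the two cores is not broken down here. In this assay compound 2 gives -87%, the lowest of the three numbers. Compound 4 `COc1cc(C(=O)/C=C/c2cc(-c3cc(OC)c(OC)c(OC)c3)n[nH]2)cc(OC)c1OC` has not yet been measured. It differs from compound 2 by methoxy in place of hydrogen on an aromatic carbon, the same kind of change as that made from compound 1 to compound 3, though here the place is also meta to a methoxy group. A smaller step in the same direction is expected, a number 8 percentage points lower from compound 2 to compound 4 (within the scatter), because compound 2 already stands at -87%. Compound 4 is therefore estimated at -95%, with a range from -108% to -80%.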

Compound 4, a percentage reported as activity, at one concentration (the size of the read-out at that concentration, not a potency): -91%
Beside the measured number, compound 4's estimate is 4 percentage points below it, within the range that was stated.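

In this assay, methoxy in place of hydrogen on an aromatic carbon, here ortho to a methoxy group and meta to a methoxy group, gives a number 4 percentage points lower from compound 2 to compound 4 (within the scatter), so on this core the change cannot be told apart from the scatter. The change does not carry over at the same size from one core to the other: the same change on two cores in this assay, a number 22 percentage points lower (beyond the scatter) from compound 1 to compound 3 and a number 4 percentage points lower (within the scatter) from compound 2 to compound 4, 18 percentage points apart, beyond the scatter of two such steps. This rests on a single pair on each core, and it does not show what makes the two steps differ.

The compounds shown leave open whether ethoxy, hydroxyl or fluorine in that place would follow methoxy on either core. From the compounds shown here alone, how these steps would read at other concentrations also stays open.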